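Methyl for methoxy on the sulfonyl aryl of compound 1

This account rests on a few compounds, and the source may have more. Where it says the series, first, only, none or still open, it means among the compounds named here.

Measured so far:
compound 1 `COc1ccc(S(=O)(=O)c2cnc3ccc(C)cc3c2N2CCC(C)CC2)cc1Cl` 93%
compound 2 `Cc1ccc(S(=O)(=O)c2cnc3cc(Cl)ccc3c2N2CCC(C)CC2)cc1` 94%
compound 3 `COc1ccc(S(=O)(=O)c2cnc3ccc(Cl)cc3c2N2CCC(C)CC2)cc1Cl` 46%

In an assay on isolated protein for displacement of a labelled ligand from metabotropic glutamate receptor 5 (Homo sapiens), with a stated time of 60 min, tested at 1 uM (a lower number here means less inhibition, a higher number more inhibition at the concentration tested (going by the name of the read-out)), compound 1 stands second highest of the three numbers. Its nearest neighbour is compound 2, which gives 94%, a difference within the scatter; the furthest is compound 3 with 46%. The one single-point step shown, a number 47 percentage points lower from compound 1 to compound 3 (beyond the scatter), is large and comes from chloro in place of methyl on an aromatic carbon of the shared core.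

Compound 4 `Cc1ccc2ncc(S(=O)(=O)c3ccc(C)c(Cl)c3)c(N3CCC(C)CC3)c2c1` differs from compound 1 at another site: methyl in place of methoxy on an aromatic carbon. No measured step bears directly on this change; the only shown step alters the core, not the sulfonyl aryl. Compound 2 carries a methyl, not a methoxy, on its sulfonyl aryl and gives 94%, but it differs from compound 1 in more than one place, so it can only hint that a methyl there goes with a number level with that of compound 1. The expectation for compound 4 is therefore a step of a number 5 percentage points lower from compound 1 to compound 4 (within the scatter), which is none beyond the scatter. The estimate for compound 4 in this assay is 88%, with a range from 70% to 98%.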

Compound 4, a percentage reported as inhibition, at one concentration (the size of the read-out at that concentration, not a potency): 91%
Compound 4: middle estimate off by 3 percentage points, on the low side, and the stated range covers the measured number.
By their numbers in this assay, from the lowest: compound 3; then compounds 4, 1 and 2 (each within the scatter of the next).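

In this assay the change at the sulfonyl aryl can now be read directly, with the chloro group and the shared core held fixed (a number 2 percentage points lower from compound 1 to compound 4 (within the scatter)). The 3-chloro-4-methoxyphenyl and 3-chloro-4-methylphenyl groups therefore cannot be told apart at the concentration tested, so the hint from compound 2 is replaced by a comparison differing in one place, and the hydrogen-bond acceptor that leaves with the methoxy is not required for a number in this range. No measurement shown gives a reason for this result.

The read-out is taken at one concentration and is not a potency, so a difference between compound 1 and compound 4 could still exist that this measure does not show. The compounds shown leave open whether an ethoxy group, an amine or a carboxylic acid on this aromatic carbon would be accepted equally, and whether the large core step (a number 47 percentage points lower from compound 1 to compound 3 (beyond the scatter)) would recur with a 3-chloro-4-methylphenyl group on the sulfonyl.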